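The source may hold more compounds than are shown below. What is called first, only, known or untested is meant among the compounds shown, and "the series" means these compounds.

In a functional assay on A-375 cells (Homo sapiens) for cytotoxicity, read by MTT assay (on this read-out higher numbers stand for weaker inhibition and lower numbers for stronger inhibition), compound 3 `COc1ccc(/C=C/C(=O)Oc2cc(/C=C/C(=O)c3ccc(OC)c4c3OC(C)(C)C=C4)ccc2OC)cc1` gives 2630 nM, the highest number of the three measured. Compound 1 `C=CC(=O)Oc1cc(/C=C/C(=O)c2ccc(OC)c3c2OC(C)(C)C=C3)ccc1OC` gives 390 nM and compound 2 `COc1ccc(/C=C/C(=O)c2ccc(OC)c3c2OC(C)(C)C=C3)cc1OC(=O)CCl` gives 450 nM. Compound 4 `COc1ccc(/C=C/C(=O)c2ccc(OC)c3c2OC(C)(C)C=C3)cc1OC(=O)c1ccco1` has furan-2-yl in place of 2-(4-methoxyphenyl)ethenyl on a carbonyl carbon. Two modest steps bear on this change, a 6.7-fold higher number from compound 1 to compound 3 (0.83 log units; beyond the scatter) and a 5.8-fold higher number from compound 2 to compound 3 (0.77 log units; beyond the scatter), and both bring in the group that compound 4 lacks. By contrast, a 1.2-fold higher number from compound 1 to compound 2 (0.06 log units; within the scatter) stays within the scatter. Among the measured compounds shown here, a modest step towards a lower number in this assay is therefore expected, though furan-2-yl itself has no measured precedent here. For compound 4 the expected value is 900 nM, with an estimated range of 300 nM to 2500 nM. The expected step is a 2.9-fold lower number from compound 3 to compound 4 (0.47 log units; beyond the scatter).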

Compound 4, half-maximal inhibitory concentration: 680 nM
Compound 4: middle estimate off by 1.3-fold (0.12 log units), on the high side, and the stated range covers the measured number.
By their numbers in this assay, from the lowest: compounds 1, 2 and 4 (each within the scatter of the next); then compound 3.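

In this assay, a ring on this carbonyl carbon does not by itself raise the number: replacing 2-(4-methoxyphenyl)ethenyl with the smaller furan-2-yl gives a 3.9-fold lower number from compound 3 to compound 4 (0.59 log units; beyond the scatter). Furan-2-yl also stays level with the open-chain groups, with a 1.5-fold higher number from compound 2 to compound 4 (0.18 log units; within the scatter) and a 1.7-fold higher number from compound 1 to compound 4 (0.24 log units; within the scatter), so compound 3 alone stands apart. No measurement available explains this separation.

Open, from the compounds shown here alone, is whether plain phenyl on this carbonyl carbon would stay with compound 4 or move towards compound 3. Aminomethyl, a basic amine-bearing chain, also remains to be placed against these groups.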